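Aryl in place of tert-butyl on the shared core

This account rests on a few compounds, and the source may have more. Where it says the series, first, only, none or still open, it means among the compounds named here.

Compound 1 `CC(C)(C)c1cn(C[C@H](O)[C@H]2OC(=O)C(OCc3ccccc3)=C2OCc2ccccc2)nn1` is the reference point of this set. In a functional assay on HCT-116 cells (Homo sapiens) for antiproliferative activity, read by MTT assay, with a stated time of 72 h (a higher number here means a weaker inhibitor, a lower number a stronger inhibitor), compound 1 gives 28300 nM, the highest of the two numbers reported; its nearest neighbour is compound 2 `Cc1ccc(S(=O)(=O)NCc2cn(C[C@H](O)[C@H]3OC(=O)C(OCc4ccccc4)=C3OCc3ccccc3)nn2)cc1`, which gives 13100 nM. Compound 3 `COc1ccccc1-c1cn(C[C@H](O)[C@H]2OC(=O)C(OCc3ccccc3)=C2OCc2ccccc2)nn1` sits at a limit of the assay rather than at a number, namely (the limit of > 100000 nM in this assay, at which 1 of the 3 values shown sits). For compound 3 the entry reads > 100000 nM.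

Two measured steps start from compound 1: a 2.2-fold lower number from compound 1 to compound 2 (0.33 log units; beyond the scatter), and an at least 3.5-fold higher number from compound 1 to compound 3 (0.54 log units; beyond the scatter). The third step, an at least 7.6-fold higher number from compound 2 to compound 3 (0.88 log units; beyond the scatter), combines the two.

Compound 4 `Cc1ccc(-c2cn(C[C@H](O)[C@H]3OC(=O)C(OCc4ccccc4)=C3OCc3ccccc3)nn2)cc1` has not yet been measured. Relative to compound 1 the change is 4-methylphenyl in place of tert-butyl on an aromatic carbon. For the measured compounds named here, the step that bears most directly on it is the one from compound 1 to compound 3, where a different aryl group took the place of the same tert-butyl and the number rose to the limit. The step to compound 2 runs the other way but involves a group of a different kind. A higher number is expected for compound 4, possibly reaching the limit again, with wide uncertainty in size. For compound 4 the estimate is 80000 nM, within 30000 nM to 250000 nM, which means a step of a 2.8-fold higher number from compound 1 to compound 4 (0.45 log units; beyond the scatter) is expected.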

Compound 4, half-maximal inhibitory concentration: > 100000 nM
Compound 4: a limit, no number; the forecaster's own chance of this, stated with the estimate: 50%; at least 1.2-fold (0.09 log units) between middle value and limit.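

With compound 4, a second aryl group on this aromatic carbon of the shared core, 4-methylphenyl in place of the 2-methoxyphenyl of compound 3, ends at a limit of this assay and not at a number: the limit of > 100000 nM in this assay, at which 2 of the 4 values shown sit. The rise seen with compound 3 is therefore not confined to the 2-methoxyphenyl group, since replacing tert-butyl with 4-methylphenyl gives an at least 3.5-fold higher number from compound 1 to compound 4 (0.54 log units; beyond the scatter). The 4-methylphenyl unit alone does not account for the result, as compound 2 also carries it, within (((4-methylphenyl)sulfonyl)amino)methyl, and the change to the directly attached group gives an at least 7.6-fold higher number from compound 2 to compound 4 (0.88 log units; beyond the scatter); the step between the two aryl compounds cannot be read, as both stand at limits.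

With two of the four compounds at the limit, the data cannot rank 4-methylphenyl against 2-methoxyphenyl, and they do not show whether an unsubstituted phenyl would behave in the same way. On these data alone, how this position responds to a primary amine, a carboxylic acid or a longer alkyl chain also remains open, as does whether any such group would give a lower number than compound 2.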